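Series notes: isopropylsulfanyl to benzylsulfanyl

The source may report more compounds than this note shows. Statements on the series, on what has been measured and on what is new or still open speak of the compounds shown alone.

Measured so far in an ADME assay on Akata cells (Homo sapiens) for cytotoxicity, with a stated time of 7 days (a higher number here means that more compound is tolerated, a lower number that less compound is tolerated), with every entry a limit
- compound 1 `CNc1nc(N)nc2c1ncn2/C=C1/CC1(CO)CO` gives > 24000 nM (limit)
- compound 2 `CCOc1nc(N)nc2c1ncn2/C=C1/CC1(CO)CO` gives > 20000 nM (limit)
- compound 3 `CC(C)Sc1nc(N)nc2c1ncn2/C=C1/CC1(CO)CO` gives > 20000 nM (limit)

Compound 3 has no number, only a limit, and stands at the limit of > 20000 nM in this assay, at which 2 of the 3 values shown sit (shared with compound 2). Compound 1 stands apart at the limit of > 24000 nM in this assay, at which 1 of the 3 values shown sits (also only a limit). No ranking of the three can be read from these entries.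

The next structure is compound 4 `Nc1nc(SCc2ccccc2)c2ncn(/C=C3/CC3(CO)CO)c2n1` with benzyl in place of isopropyl on a sulfur (not yet measured).

Two measured steps reach compound 3 by a change of group on an aromatic carbon, a step that the two limits leave unreadable from compound 1 to compound 3 and a step that the two limits leave unreadable from compound 2 to compound 3 (neither gives a size). With no readable step to carry over, no step beyond the scatter is expected, and no direction is favoured. The expected change is a number no higher from compound 3 to compound 4 (the limit leaves the size open) (an estimate only). For compound 4 the estimated value is 20000 nM (expected range 8000 nM to 40000 nM), quite possibly reported only as a limit.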

Compound 4, half-maximal cytotoxic concentration: > 20000 nM
Compound 4 was reported as a limit (the forecaster's own chance of this, stated with the estimate: 70%); the middle value lies on the limit itself.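

In this assay compound 4 gives > 20000 nM, which is a limit. Its steps from compound 1, compound 2 and compound 3 cannot be read. The compounds shown leave open the actual half-maximal cytotoxic concentration of each compound, and whether any of these changes of group shifts it.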